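The compounds below may be only part of what the source reports. "The series", "measured", "known", "first", "only" and "open" are said of these compounds alone.

Going by the values given here, in a functional assay on HL-60 cells (Homo sapiens) for antiproliferative activity, read by XTT assay, with a stated time of 72 h (a higher number here means a weaker inhibitor, a lower number a stronger inhibitor), compound 3 `C#Cc1cn([C@@H]2O[C@H](CO)[C@@H](O)[C@H]2O)c2ncnc(OC)c12` gives 190 nM, the highest of the three numbers measured so far. Compound 1 `COc1ncnc2c1c(-c1ccoc1)cn2[C@@H]1O[C@H](CO)[C@@H](O)[C@H]1O` gives 150 nM, and the step of a 1.3-fold higher number from compound 1 to compound 3 (0.10 log units; within the scatter) is within the scatter. Compound 2 `COc1ncnc2c1c(-c1cccs1)cn2[C@@H]1O[C@H](CO)[C@@H](O)[C@H]1O` gives 80 nM, and the step of a 2.4-fold higher number from compound 2 to compound 3 (0.38 log units; beyond the scatter) is modest. Compound 4 `COc1ncnc2c1c(I)cn2[C@@H]1O[C@H](CO)[C@@H](O)[C@H]1O` differs from compound 3 at the same aromatic carbon where these three groups were exchanged: iodo in place of ethynyl on an aromatic carbon. The measured steps of a 1.9-fold lower number from compound 1 to compound 2 (0.27 log units; within the scatter), a 1.3-fold higher number from compound 1 to compound 3 (0.10 log units; within the scatter) and a 2.4-fold higher number from compound 2 to compound 3 (0.38 log units; beyond the scatter) show that swapping groups at this carbon moved the number only slightly, so no step beyond the scatter is expected here. Compound 4 is therefore estimated at 200 nM, between 80 nM and 500 nM, a step of a 1.1-fold higher number from compound 3 to compound 4 (0.02 log units; within the scatter) from compound 3.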

Compound 4, half-maximal inhibitory concentration: 2300 nM
Estimate against measurement, compound 4: 12-fold (1.06 log units) below; the whole stated range lies below it.
By their numbers in this assay, from the lowest: compounds 2, 1 and 3 (each within the scatter of the next, the first and the last beyond it); then compound 4.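

In this assay, this aromatic carbon proves sensitive to what it carries: iodo in place of ethynyl gives a 12-fold higher number from compound 3 to compound 4 (1.08 log units; beyond the scatter), and the comparisons with the two ring-bearing compounds are larger still, with a 29-fold higher number from compound 2 to compound 4 (1.46 log units; beyond the scatter) and a 15-fold higher number from compound 1 to compound 4 (1.19 log units; beyond the scatter). Ethynyl, furan-3-yl and thiophen-2-yl differed far less among themselves, so the earlier compounds alone gave no sign that a swap here could cost this much. No measurement at hand accounts for the drop. From the compounds shown here alone, whether chloro or an amine at this carbon would stay with those three groups or fall with iodo remains open.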